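A few compounds are considered here, and "the series" means these few. Any claim that something is new, unique, unknown or untested is made for them only; others in the source may bear on it.

Measured compounds:
compound 1 `Cn1cc(-c2cnc(N)c(Oc3ccc(C(=O)Nc4ccccc4)cc3)n2)cn1` — 12300 nM
compound 2 `Cn1cc(-c2cnc(N)c(Oc3ccc(C(=O)Nc4ccc(Cl)cc4)cc3)n2)cn1` — 3440 nM
compound 3 `Cn1cc(-c2cnc(N)c(Oc3ccc(C(=O)Nc4cc(Cl)ccn4)cc3)n2)cn1` — 40800 nM

All three were tested in a functional assay on HeLa cells (Homo sapiens) for inhibition, read by MTT assay, with a stated time of 72 h; a lower number here means a stronger inhibitor, a higher number a weaker inhibitor. Compound 3 stands at the weak end of the set: its number is the highest of the three, with compound 1 nearest (a 3.3-fold higher number from compound 1 to compound 3 (0.52 log units; beyond the scatter)) and compound 2 furthest (a 12-fold higher number from compound 2 to compound 3 (1.07 log units; beyond the scatter)). The step from compound 1 to compound 2 was modest in the other direction (a 3.6-fold lower number from compound 1 to compound 2 (0.55 log units; beyond the scatter)).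

Compound 4 `Cn1cc(-c2cnc(N)c(Oc3ccc(C(=O)Nc4ncccc4Cl)cc3)n2)cn1` differs from compound 3 only in where the chlorine sits on the pyridine ring: 3-chloropyridin-2-yl in place of 4-chloropyridin-2-yl on an amide-type nitrogen. Within the data shown here, none of the measured steps moves a substituent around a ring; the two steps that involve the pyridine both replace a phenyl-type group with a pyridine, and the one chloro step adds a chlorine to a phenyl. Nothing here bears directly on shifting the chlorine within the pyridine, so no step beyond the scatter is expected in this assay for compound 4, and the estimate is a 1.0-fold lower number from compound 3 to compound 4 (0.01 log units; within the scatter). Compound 4 is therefore expected to give about 40000 nM, within a range of 14000 nM to 115000 nM.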

Compound 4, half-maximal inhibitory concentration: 36100 nM
For compound 4 the middle estimate is 1.1-fold (0.04 log units) above the measured one, within the range that was stated.
By their numbers in this assay, from the lowest: compound 2; then compound 1; then compounds 4 and 3 (each within the scatter of the next).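

In this assay the chlorine can sit in either place on the pyridine with no reading difference, a 1.1-fold lower number from compound 3 to compound 4 (0.05 log units; within the scatter), so at this amide-type nitrogen 3-chloropyridin-2-yl and 4-chloropyridin-2-yl cannot be told apart. The weaker result for a chloropyridine therefore does not depend on one chlorine placement: the replacement of 4-chlorophenyl gives a 10-fold higher number from compound 2 to compound 4 (1.02 log units; beyond the scatter), and the replacement of phenyl gives a 2.9-fold higher number from compound 1 to compound 4 (0.47 log units; beyond the scatter), the same direction that compound 3 showed against both compounds. No measured evidence is available to explain this result.

Going by these compounds, it remains open how an unsubstituted pyridin-2-yl on the same nitrogen would read, which would show what the ring alone contributes apart from the chlorine. Also open, on these data alone, is whether a fluorine, a methyl or a methoxy group in place of the chlorine on the pyridine would recover the number seen with the chlorophenyl compound.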